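A few compounds are considered here, and "the series" means these few. Any claim that something is new, unique, unknown or untested is made for them only; others in the source may bear on it.

Series of diamides on one shared core, compound 2 `CN(C(=O)CC(CC(=O)NCCN1CCCC1)c1ccc(Cl)cc1)C1Cc2ccccc2C1`, alongside its des-chloro analogue compound 1 `CN(C(=O)CC(CC(=O)NCCN1CCCC1)c1ccccc1)C1Cc2ccccc2C1`, the ethyl-bearing compound 3 `CCNCCNC(=O)CC(CC(=O)N(CC)C1Cc2ccccc2C1)c1ccc(Cl)cc1` and the still unmeasured compound 4 `CCNCCNC(=O)CC(CC(=O)N(CC)C1Cc2ccccc2C1)c1ccccc1`. In a functional assay on HeLa cells (Homo sapiens) for inhibition (on this read-out lower numbers stand for stronger inhibition and higher numbers for weaker inhibition), compound 2 gives 55400 nM. Compound 1 reaches only a limit of this read-out, > 100000 nM, and that value is a limit rather than a number. The change hydrogen in place of chloro on an aromatic carbon thus produces an at least 1.8-fold higher number from compound 2 to compound 1 (0.25 log units; that floor lies within the scatter), and the end point sits at the limit of > 100000 nM in this assay, at which 1 of the 3 values shown sits. In this assay compound 3 gives 40500 nM; the difference between the core of compound 3 and the core of compound 2 is not broken down here, and the two values lie within the scatter of each other.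

Compound 4 repeats on the core of compound 3 the change that leads from compound 2 to compound 1: hydrogen in place of chloro on an aromatic carbon. The two places are described in identical words, so this is the same change, not merely the same kind. Given the direction shown by an at least 1.8-fold higher number from compound 2 to compound 1 (0.25 log units; that floor lies within the scatter), the number for compound 4 is expected to move upward, with a step estimated at a 2.0-fold higher number from compound 3 to compound 4 (0.30 log units; within the scatter). Compound 4 is therefore estimated at 80000 nM in this assay, with a range from 40000 nM to 160000 nM. Going by the values given here, a limit rather than a number is a real possibility for compound 4, since the only measured step of this change an at least 1.8-fold higher number from compound 2 to compound 1 (0.25 log units; that floor lies within the scatter) ended at the limit of > 100000 nM in this assay, at which 1 of the 3 values shown sits.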

Compound 4, half-maximal inhibitory concentration: > 100000 nM
Compound 4 ended at the assay's limit; the forecaster's own chance of this, stated with the estimate: 35%; middle value at least 1.2-fold (0.09 log units) away from the limit.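

On the core of compound 3, replacing 4-chlorophenyl with phenyl gives an at least 2.4-fold higher number from compound 3 to compound 4 (0.39 log units; beyond the scatter) in this assay, which is a clear loss of inhibition and runs in the same direction as the step on the other core, an at least 1.8-fold higher number from compound 2 to compound 1 (0.25 log units; that floor lies within the scatter). Going by these compounds alone, the change therefore carries across these two cores in direction, with the chloro compound the stronger of each pair, although only the step on the core of compound 3 clears the scatter. The size of the step is not shown to carry over, and no claim of equal or unequal steps can be made: the same change on two cores in this assay, an at least 1.8-fold higher number (0.25 log units; that floor lies within the scatter) from compound 2 to compound 1 and an at least 2.4-fold higher number (0.39 log units; beyond the scatter) from compound 3 to compound 4; the limit leaves it open whether they differ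

Compound 1 and compound 4 both stop at a limit of the read-out rather than at a number, so each step is only a floor: the limit of > 100000 nM in this assay, at which 2 of the 4 values shown sit.

The compounds shown leave open whether another group in the place of the chloro, such as fluoro, bromo, methyl or methoxy, would keep or improve on the inhibition seen with 4-chlorophenyl. They also leave open how far the amine end of the chain can be varied, for example with a primary amine, a piperidine or a carboxylic acid, and whether the same change behaves alike on such cores.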